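A few compounds are considered here, and "the series" means these few. Any claim that something is new, unique, unknown or untested is made for them only; others in the source may bear on it.

Measured so far in an assay on isolated protein (artery, Oryctolagus cuniculus) with Substance-P receptor (Homo sapiens) as the target; on this read-out lower numbers stand for tighter binding and higher numbers for weaker binding:
compound 1 `O=C1CCC(CCN2CC(N3CCNCC3)C2)(c2ccc(Cl)c(Cl)c2)CN1Cc1ccccc1` — 5.01 nM
compound 2 `CS(=O)(=O)N1CCN(C2CN(CCC3(c4ccc(Cl)c(Cl)c4)CCC(=O)N(Cc4ccccc4)C3)C2)CC1` — 0.631 nM

Compound 1 gives the highest of the two numbers in this assay; the nearest is compound 2, reached by a 7.9-fold lower number from compound 1 to compound 2 (0.90 log units; beyond the scatter). Among the measured compounds shown here, the only change covered by measurement is therefore the methylsulfonyl in place of hydrogen on an amine nitrogen in a ring. Compound 3 `O=C1CCC(CCN2CC(N3CCCC(O)C3)C2)(c2ccc(Cl)c(Cl)c2)CN1Cc1ccccc1` differs from compound 1 in another way: 3-hydroxypiperidin-1-yl in place of piperazin-1-yl on a saturated ring carbon. For the measured compounds named here, the piperazin-1-yl that leaves is the ring on which the methylsulfonyl of compound 2 sits, so the one known step touches the same ring but is not the same kind of change; the entering 3-hydroxypiperidin-1-yl keeps 1 hydrogen-bond donor and 2 hydrogen-bond acceptors, now on a six-membered non-aromatic ring with 1 hetero atom. Going by the values given here, no measured step bears directly on this exchange. A step of a 1.3-fold lower number from compound 1 to compound 3 (0.10 log units; within the scatter) is expected, with a result within the usual scatter the most likely outcome. Compound 3 is estimated at 4 nM, within 1 nM to 15 nM.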

Compound 3, dissociation constant: 2 nM
Compound 3: middle estimate off by 2.0-fold (0.30 log units), on the high side, within the range that was stated.
By their numbers in this assay, from the lowest: compound 2; then compound 3; then compound 1.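

In this assay, the saturated ring carbon of the four-membered ring accepts a piperazin-1-yl replacement that has no methylsulfonyl: 3-hydroxypiperidin-1-yl in place of piperazin-1-yl gives a 2.5-fold lower number from compound 1 to compound 3 (0.40 log units; beyond the scatter), so the second ring nitrogen of the piperazine is not needed for a lower number. The methylsulfonyl-bearing ring still holds the lowest number of the three, with 3-hydroxypiperidin-1-yl in place of 4-(methylsulfonyl)piperazin-1-yl giving a 3.2-fold higher number from compound 2 to compound 3 (0.50 log units; beyond the scatter). No supporting data are available to explain either step.

Open, going by these compounds, is how the gain divides between the loss of the ring nitrogen and the entry of the hydroxyl, which the plain piperidin-1-yl group would separate. Also open, on these data alone, is whether a 4-acetylpiperazin-1-yl group or a morpholin-4-yl group would fall nearer the methylsulfonyl-bearing ring or the 3-hydroxypiperidin-1-yl ring.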